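Amide to urea on the shared core: compound 4

The source may hold more compounds than are shown below. What is called first, only, known or untested is meant among the compounds shown, and "the series" means these compounds.

Measured compounds:
compound 1 `CNC(=O)c1cc(Oc2ccc3nc(NC(=O)c4ccc(Cl)cc4Cl)sc3c2)ccn1`: 64.4%
compound 2 `CNC(=O)c1cc(Oc2ccc3nc(NC(=O)Nc4ccc(Cl)cc4)sc3c2)ccn1`: 85.2%
compound 3 `CNC(=O)c1cc(Oc2ccc3nc(NC(=O)Nc4ccc(Br)cc4)sc3c2)ccn1`: 80%

In a functional assay on HCT-116 cells (Homo sapiens) for inhibition, read by MTT assay, with a stated time of 2 days, tested at 100 uM (on this read-out higher numbers stand for more inhibition of growth at the one concentration tested and lower numbers for less inhibition of growth), compound 1 gives 64.4%, the lowest of the three numbers. The nearest is compound 3, reached by a number 15.6 percentage points higher from compound 1 to compound 3 (beyond the scatter); the furthest is compound 2, reached by a number 20.8 percentage points higher from compound 1 to compound 2 (beyond the scatter). Between those two, a number 5.2 percentage points lower from compound 2 to compound 3 (within the scatter) shows that the halogen swap alone does nothing that can be separated from noise.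

Compound 4 `CNC(=O)c1cc(Oc2ccc3nc(NC(=O)Nc4ccc(Cl)cc4Cl)sc3c2)ccn1` differs from compound 1 by (2,4-dichlorophenyl)amino in place of 2,4-dichlorophenyl on a carbonyl carbon. Both steps from compound 1 bear on this: each replaced the 2,4-dichlorophenyl on the carbonyl carbon by an arylamino group and each went up beyond the scatter, though each also changed the aryl substitution at the same time. Among the compounds with values here, no measured step isolates the amide-to-urea change with the 2,4-dichlorophenyl kept, so the expectation rests on the two combined steps. On that basis compound 4 is expected to show an increase of a number 13.6 percentage points higher from compound 1 to compound 4 (beyond the scatter), modest in size. The estimate for compound 4 is 78%, with a range from 62% to 92%.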

Compound 4, percent growth inhibition at one concentration: 93.6%
Compound 4: middle estimate off by 15.6 percentage points, on the low side; the measured number lies above the stated range.
By their numbers in this assay, from the lowest: compound 1; then compounds 3, 2 and 4 (each within the scatter of the next, the first and the last beyond it).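

Within the data shown here, with the 2,4-dichlorophenyl kept, the amide-to-urea change on the carbonyl carbon stands alone for the first time: in this assay there is a number 29.2 percentage points higher from compound 1 to compound 4 (beyond the scatter) and no change in aryl substitution contributes to it. Among the ureas, the added chloro gives a number 8.4 percentage points higher from compound 2 to compound 4 (within the scatter) and so cannot be separated from the monochloro urea, while a number 13.6 percentage points higher from compound 3 to compound 4 (beyond the scatter) does separate the 2,4-dichlorophenyl urea from the 4-bromophenyl urea, a step that changes the halogen as well as adding a chloro. Nothing measured in this set gives a reason for these steps.

From the compounds shown here alone, whether the gain survives a methyl group on the urea nitrogen, or a cyclohexyl ring in place of the aryl ring, stays open. Readings at one concentration also leave open how these ureas would rank across a range of concentrations.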